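A few compounds are considered here, and "the series" means these few. Any claim that something is new, unique, unknown or untested is made for them only; others in the source may bear on it.

The measured compounds:
compound 1 `O=C(O)/C(S)=C/c1c[nH]c2cc(Cl)ccc12` gives 210 nM
compound 2 `O=C(O)/C(S)=C/c1cccc(F)c1` gives 19000 nM
compound 3 `O=C(O)/C(S)=C/c1ccc(I)cc1` gives 2200 nM

In an assay on isolated protein for inhibition of Calpain-1 catalytic subunit (Sus scrofa), read by FRET (on this read-out lower numbers stand for stronger inhibition and higher numbers for weaker inhibition), compound 3 stands second highest of the three numbers. Compound 2 lies above it, beyond the scatter, and compound 1 lies below it, also beyond the scatter. The step from compound 3 leads to compound 4 `O=C(O)/C(S)=C/c1ccc(Br)cc1`, with the change (bromo in place of iodo on an aromatic carbon), bromo in place of iodo on an aromatic carbon. Among the compounds with values here, no pair of measured compounds differing in a single place is available, so the size of such a halogen swap cannot be read from the data. The expected step of a 1.3-fold higher number from compound 3 to compound 4 (0.10 log units; within the scatter) is small, with no direction claimed beyond the scatter. Compound 4 is estimated at 2800 nM, in a range from 1200 nM to 7000 nM.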

Compound 4, half-maximal inhibitory concentration: 1500 nM
Beside the measured number, compound 4's estimate is 1.9-fold (0.27 log units) above it; low and high end bracket the measured number.
By their numbers in this assay, from the lowest: compound 1; then compounds 4 and 3 (each within the scatter of the next); then compound 2.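

In this assay, replacing iodo with bromo on an aromatic carbon gives a 1.5-fold lower number from compound 3 to compound 4 (0.17 log units; within the scatter), the only single-place comparison among these compounds. At this position, para to a group of 6 heavy atoms, the two halogens cannot be told apart, as the step lies within the scatter. Nothing available offers an explanation for this result. Going by these compounds, whether an amine, a methoxy group or a nitrile on this carbon would shift the number beyond the scatter remains open. So does how chloro or fluoro at this same position would compare with bromo.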